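The source may hold more compounds than are shown below. What is called first, only, known or untested is meant among the compounds shown, and "the series" means these compounds.

Among the measured compounds shown here, in a functional assay on MCF7 cells (Homo sapiens) for cytotoxicity, read by CCK-8 assay, with a stated time of 48 h (on this read-out lower numbers stand for stronger inhibition and higher numbers for weaker inhibition), compound 3 `CC(C)(C)c1cc(C(C)(C)C)c2oc(=O)c(/C=N/c3ccc(S(=O)(=O)Nc4nccs4)cc3)c(Cl)c2c1` gives 12 nM, the lowest of the three numbers measured so far. Compound 1 `Cc1cc(C)nc(NS(=O)(=O)c2ccc(/N=C/c3c(Cl)c4ccccc4oc3=O)cc2)n1` gives 20 nM, and compound 2 `Cc1ccnc(NS(=O)(=O)c2ccc(/N=C/c3c(Cl)c4ccccc4oc3=O)cc2)n1` gives 31 nM; the gap from compound 3 to compound 1 lies within the scatter, while the gap to compound 2 lies beyond it. For the measured compounds named here, the only measured step between neighbouring structures, a 1.6-fold higher number from compound 1 to compound 2 (0.19 log units; within the scatter), concerns a different part of the molecule and so says nothing direct about the change followed here. Compound 4 `Cc1cc(C)nc(NS(=O)(=O)c2ccc(/N=C/c3c(Cl)c4cc(C(C)(C)C)cc(C(C)(C)C)c4oc3=O)cc2)n1` differs from compound 3 by 4,6-dimethylpyrimidin-2-yl in place of 1,3-thiazol-2-yl on a sulfonamide nitrogen. Going by the values given here, no measured pair shows this exchange on its own, so in this assay no step beyond the scatter is expected, a 1.2-fold higher number from compound 3 to compound 4 (0.07 log units; within the scatter). Compound 4 is therefore estimated at 14 nM, with a range from 6 nM to 35 nM.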

Compound 4, half-maximal inhibitory concentration: 8.8 nM
Estimate against measurement, compound 4: 1.6-fold (0.20 log units) above; low and high end bracket the measured number.
By their numbers in this assay, from the lowest: compounds 4, 3, 1 and 2 (each within the scatter of the next, the first and the last beyond it).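

The exchange on the sulfonamide nitrogen can now be read directly in this assay: a 1.4-fold lower number from compound 3 to compound 4 (0.13 log units; within the scatter). On this core, then, 4,6-dimethylpyrimidin-2-yl, with 8 heavy atoms, and 1,3-thiazol-2-yl, with 5, cannot be told apart by this read-out, so this position accepts either ring. No evidence is available that bears on this result.
Open, going by these compounds, is whether other groups on that nitrogen, such as a plain phenyl ring or a short alkyl chain, would also give numbers within the scatter of these two.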